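The source may report more compounds than this note shows. Statements on the series, on what has been measured and on what is new or still open speak of the compounds shown alone.

Measured in a functional assay on KB cells (Homo sapiens) for cytotoxicity, read by sulforhodamine B assay, with a stated time of 3 days; a higher number here means that more compound is needed for the effect, a lower number that less compound is needed:

- compound 1 `COc1c(-c2occ(C)c2C(=O)O)ccc2c1CCCC2(C)C` gives 43.3 uM
- compound 2 `COc1c(-c2occ(C)c2COC(C)=O)ccc2c1CCCC2(C)C` gives 25.4 uM
- compound 3 `CCOc1c(-c2occ(C)c2CO)ccc2c1CCCC2(C)C` gives 16.9 uM

Compound 3 has the lowest of these three numbers. Its gap to compound 1 lies beyond the scatter, but its gap to compound 2 lies within it, so those two cannot be told apart.

Compound 4 `COc1c(-c2occ(C)c2CO)ccc2c1CCCC2(C)C` differs from compound 3 by hydrogen in place of methyl on a saturated chain carbon bound to an oxygen on an aromatic ring, which turns ethoxy into methoxy. Going by the values given here, no measured pair isolates this change. Among the compounds with values here, the only measured step, a 1.7-fold lower number from compound 1 to compound 2 (0.23 log units; within the scatter), lies elsewhere on the molecule and stays within the scatter. A small change is therefore expected, with no shift beyond the scatter in this assay and no clear direction. The expected step is a 1.2-fold higher number from compound 3 to compound 4 (0.07 log units; within the scatter). For compound 4 the estimated value is 20 uM, with an expected range of 9 uM to 42 uM.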

Compound 4, concentration for half-maximal effect: 25.3 uM
Estimate against measurement, compound 4: 1.3-fold (0.10 log units) below; measured number inside the range.
By their numbers in this assay, from the lowest: compounds 3, 4, 2 and 1 (each within the scatter of the next, the first and the last beyond it).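

In this assay, going by these compounds alone, the change from ethoxy to methoxy gives no shift that can be told from the scatter (a 1.5-fold higher number from compound 3 to compound 4 (0.18 log units; within the scatter)), the first direct reading of this position. Elsewhere on the molecule, removing the acetyl from the oxygen (a 1.0-fold lower number from compound 2 to compound 4 (0.00 log units; within the scatter)) and replacing carboxy with hydroxymethyl (a 1.7-fold lower number from compound 1 to compound 4 (0.23 log units; within the scatter)) also stay within the scatter. Nothing available here explains these small steps.

From the compounds shown here alone, whether a longer chain such as butoxy would shift the number beyond the scatter remains open. The same holds for an amine in place of hydroxymethyl.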